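The source may hold more compounds than are shown below. What is called first, only, known or untested is meant among the compounds shown, and "the series" means these compounds.

In an assay for inhibition of Alpha amylase (Homo sapiens), with a stated time of 10 min (a higher number here means a weaker inhibitor, a lower number a stronger inhibitor), compound 2 `Oc1c(Br)cc(Cl)cc1-c1nc2cc(Cl)ccc2[nH]1` gives 2860 nM. Compound 1 `Oc1c(Br)cc(Cl)cc1-c1nc2ccccc2[nH]1` gives 2850 nM in this assay, and the two numbers sit together within the scatter. Compound 3 `O=[N+]([O-])c1ccc2[nH]c(-c3cc(Cl)cc(Br)c3O)nc2c1` carries nitro in place of chloro on an aromatic carbon. For the measured compounds named here, the only measured step touching this part of the molecule, a 1.0-fold higher number from compound 1 to compound 2 (0.00 log units; within the scatter), put chloro on an aromatic carbon without moving the number beyond the scatter, so replacing that chloro with nitro is expected to bring little change. For compound 3 the expected step is a 1.0-fold lower number from compound 2 to compound 3 (0.01 log units; within the scatter), with no clear direction. Compound 3 is therefore estimated at 2800 nM, with a range from 1100 nM to 7500 nM.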

Compound 3, half-maximal inhibitory concentration: 2870 nM
Compound 3: the middle estimate sits 1.0-fold (0.01 log units) below what was measured, within the range that was stated.
By their numbers in this assay, from the lowest: compounds 1, 2 and 3 (each within the scatter of the next).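

Replacing chloro with nitro, a larger group with three heavy atoms and two hydrogen-bond acceptors, leaves the number in this assay within the scatter (a 1.0-fold higher number from compound 2 to compound 3 (0.00 log units; within the scatter)). The comparison with hydrogen also stays within the scatter (a 1.0-fold higher number from compound 1 to compound 3 (0.00 log units; within the scatter)), so hydrogen, chloro and nitro cannot be told apart at this position in this assay. Nothing shown explains why this position accepts all three. As far as these compounds go, whether an amine, a carboxylic acid or a longer chain here would also leave the number unchanged remains open.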